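Oximino ethers: moving from 2-chlorobenzyl to 3,4-dichlorobenzyl

The source may hold more compounds than are shown below. What is called first, only, known or untested is meant among the compounds shown, and "the series" means these compounds.

Compound 1, `Clc1ccccc1CO/N=C/c1c(-c2ccc3ccccc3c2)nc2occn12`, gives 1100 nM in an assay on HepG2 cells for agonist activity at nuclear receptor subfamily 1 group I member 3 (Homo sapiens), read by a luciferase reporter, with a stated time of 23 h; a higher number here means that more compound is needed for the effect, a lower number that less compound is needed. Compound 2, `CC(C)c1ccc(-c2nc3sccn3c2/C=N/OCc2ccc(Cl)c(Cl)c2)cc1`, gives 590 nM in this assay; the two numbers lie within the scatter of each other, so no order between them can be read, and compound 2 shares neither core nor aryl group with compound 1. Compound 3, `Clc1ccc(CO/N=C/c2c(-c3ccc4ccccc4c3)nc3occn23)cc1Cl`, differs from compound 1 by 3,4-dichlorophenyl in place of 2-chlorophenyl on a saturated chain carbon bound to an oxygen on an unsaturated carbon. For the measured compounds named here, no measured pair isolates this change. The step from compound 1 to compound 3 is expected to be small, if anything toward a lower number, and is estimated as a 1.5-fold lower number from compound 1 to compound 3 (0.17 log units; within the scatter). Compound 3 is expected to give about 750 nM, with a range of 300 nM to 1900 nM.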

Compound 3, half-maximal effective concentration: 370 nM
For compound 3 the middle estimate is 2.0-fold (0.31 log units) above the measured one, within the range that was stated.
By their numbers in this assay, from the lowest: compounds 3, 2 and 1 (each within the scatter of the next, the first and the last beyond it).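

On the saturated chain carbon bound to an oxygen on an unsaturated carbon, 3,4-dichlorophenyl in place of 2-chlorophenyl gives a 3.0-fold lower number from compound 1 to compound 3 (0.47 log units; beyond the scatter) in this assay. For the compounds shown here, this is the first single-place comparison, and it shows that the number responds to the group at this position while the rest of compound 1 stays the same. No available data account for this step.

Left open is whether 4-chlorophenyl alone would read like 3,4-dichlorophenyl at this place. Also open, going by these compounds, are how a carboxylic acid there would read and whether the step carries over to the core of compound 2.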